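The compounds below may be only part of what the source reports. "The series", "measured", "known", "first", "only" and "open" are said of these compounds alone.

Series notes. Within the data shown here, compound 1 `COc1cc(-c2nc3cc([N+](=O)[O-])ccc3[nH]2)ccc1O` carries the nitro group on the shared core; in a functional assay on aorta (Rattus norvegicus, strain Wistar) for inhibition, with a stated time of 60 min (a lower number here means that less compound is needed, a higher number that more compound is needed for the effect), compound 1 gives 1810 nM, the lowest of the three numbers measured so far. Compound 2 `COc1cc(-c2nc3cc(C(F)(F)F)ccc3[nH]2)ccc1O` gives 34800 nM, and a 19-fold higher number from compound 1 to compound 2 (1.28 log units; beyond the scatter). Among the measured compounds shown here, compound 3 `COc1ccccc1-c1nc2cc(C(F)(F)F)ccc2[nH]1` gives 210000 nM; no single-change step connects it to either of the other two, so only the two values themselves can be compared. Compound 4 `COc1ccc(-c2nc3cc([N+](=O)[O-])ccc3[nH]2)cc1OC` is not yet measured; it differs from compound 1 by methyl in place of hydrogen on an oxygen on an aromatic ring. For the measured compounds named here, the one measured step concerns a different group, so no step bears directly on this change. Without a guide, a modest loss relative to compound 1 is expected, a 2.2-fold higher number from compound 1 to compound 4 (0.34 log units; beyond the scatter). For compound 4 the estimate is 4000 nM, with a range of 1000 nM to 15000 nM.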

Compound 4, half-maximal effective concentration: 2500 nM
Beside the measured number, compound 4's estimate is 1.6-fold (0.20 log units) above it; measured number inside the range.
By their numbers in this assay, from the lowest: compounds 1 and 4 (each within the scatter of the next); then compound 2; then compound 3.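

In this assay, hydroxy to methoxy on this oxygen gives a 1.4-fold higher number from compound 1 to compound 4 (0.14 log units; within the scatter). The free hydrogen on this oxygen is therefore not needed to keep the number in this range, at least with nitro on the shared core. No measurement on hand accounts for this result.

Still open, from the compounds shown here alone, is whether a longer chain on this oxygen, or an amine in place of the hydroxy, would stay within the scatter of compound 1. Going by these compounds, it is also open whether hydroxy to methoxy would read the same on compound 2, which carries trifluoromethyl.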